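Amide nitrogen substituents in a tolyloxyacetamide series

The source may report more compounds than this note shows. Statements on the series, on what has been measured and on what is new or still open speak of the compounds shown alone.

Going by the values given here, in an assay on HEK293 cells for agonist activity at transient receptor potential cation channel subfamily M member 8 (Homo sapiens), read by fluorescence and calcium flux, with a stated time of 15 min (on this read-out higher numbers stand for an effect only at larger amounts of compound and lower numbers for an effect already at smaller amounts), compound 2 `Cc1ccc(OCC(=O)N(Cc2cccs2)c2ncccn2)cc1` gives 3700 nM, the second highest of the three numbers so far. Compound 1 `CCN(Cc1cccs1)C(=O)COc1ccc(C(C)C)cc1` gives 397 nM, and compound 3 `CCN(Cc1cc[nH]c1)C(=O)COc1ccc(C)cc1` gives 21800 nM; both gaps to compound 2 lie beyond the scatter. Among the compounds with values here, no single-change step between measured compounds is available, so the weight of the amide nitrogen substituent can only be inferred.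

Compound 4 `COCCN(Cc1cccs1)C(=O)COc1ccc(C)cc1` differs from compound 2 by 2-methoxyethyl in place of pyrimidin-2-yl on an amide-type nitrogen. In this assay a moderate step toward a lower number is expected, a 2.5-fold lower number from compound 2 to compound 4 (0.39 log units; beyond the scatter), since compound 1, which also carries a saturated chain on that nitrogen, gives 397 nM. Compound 4 is estimated at 1500 nM, with a range from 400 nM to 6000 nM.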

Compound 4, half-maximal effective concentration: 400 nM
Estimate against measurement, compound 4: 3.8-fold (0.57 log units) above; the measured number falls inside the stated range.
By their numbers in this assay, from the lowest: compounds 1 and 4 (each within the scatter of the next); then compound 2; then compound 3.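

Going by these compounds alone, with a 9.3-fold lower number from compound 2 to compound 4 (0.97 log units; beyond the scatter), this gives the first single-change reading at the amide-type nitrogen in this assay, showing that this substituent alone can move the number beyond the scatter. The lower number comes with a ring-free chain replacing the six-membered aromatic ring, so an aromatic ring is not required at this position. No supporting data explain the step.

The step does not separate the loss of the ring from the gain of the ether oxygen. Phenyl or 2-hydroxyethyl on the same nitrogen would help to separate these two contributions.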